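Swapping fluoro for methyl on the aryl ring of hydroxamic acids

The compounds below may be only part of what the source reports. "The series", "measured", "known", "first", "only" and "open" are said of these compounds alone.

Measured compounds and values:
Compound 1, `CCc1cc(-c2ccc(F)cc2)nn1Cc1ccc(C(=O)NO)cc1`: 16700 nM
Compound 2, `CCCc1cc(-c2ccc(F)cc2)nn1Cc1ccc(C(=O)NO)cc1`: 16800 nM
Compound 3, `Cc1cc(-c2ccc(F)cc2)nn1Cc1ccc(C(=O)NO)cc1`: 30000 nM

In a functional assay on HepG2 cells (Homo sapiens) for antiproliferative activity, read by MTT assay, with a stated time of 96 h (a higher number here means a weaker inhibitor of growth, a lower number a stronger inhibitor of growth), compound 3 gives the highest of the three numbers, yet a 1.8-fold higher number from compound 1 to compound 3 (0.25 log units; within the scatter) and a 1.8-fold higher number from compound 2 to compound 3 (0.25 log units; within the scatter) show that neither step separates it from the others. Compound 4, `Cc1ccc(-c2cc(C)n(Cc3ccc(C(=O)NO)cc3)n2)cc1`, differs from compound 3 by methyl in place of fluoro on an aromatic carbon, on an aromatic carbon of a six-membered aromatic ring of carbon only, para to a large group. Going by the values given here, no measured step touches this ring: the three known steps, a 1.0-fold higher number from compound 1 to compound 2 (0.00 log units; within the scatter) among them, all change the saturated chain on the shared core and all lie within the scatter. There is thus no basis for a shift beyond the scatter in this assay. Compound 4 is expected to give 30000 nM, between 12000 nM and 75000 nM. For compound 4 the estimated step is no change at the digits printed from compound 3 to compound 4 (within the scatter).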

Compound 4, concentration for 50% growth inhibition: 21200 nM
The estimate for compound 4 lay 1.4-fold (0.15 log units) above the measured number; low and high end bracket the measured number.
By their numbers in this assay, from the lowest: compounds 1, 2, 4 and 3 (each within the scatter of the next).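

In this assay the first change shown on the aryl ring, 4-fluorophenyl to 4-methylphenyl, gives a 1.4-fold lower number from compound 3 to compound 4 (0.15 log units; within the scatter) and so stays within the scatter. On this aromatic carbon, para to a large group, methyl in place of fluoro therefore leaves the number as unresolved as the chain steps on the shared core did. Nothing measured here bears on this result.

Going by these compounds, whether an amine, a carboxylic acid or a methoxy group at this position would move the number beyond the scatter stays open. So does whether 4-methylphenyl gives the same result with the ethyl chain of compound 1 or the propyl chain of compound 2.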